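The source may report more compounds than this note shows. Statements on the series, on what has been measured and on what is new or still open speak of the compounds shown alone.

Compound 1, `CN1CCC[C@H]1COc1cccnc1Br`: 7.1%
Compound 2, `Cc1ccncc1OC[C@@H]1CCCN1C`: 12%

Of the compounds shown here, two have been measured so far. In an assay on IMR-32 cells with Neuronal acetylcholine receptor; alpha4/beta2 (Homo sapiens) as the target (on this read-out higher numbers stand for larger maximal responses and lower numbers for smaller maximal responses), compound 1 gives 7.1%, and compound 2 gives 12%. The two numbers lie within the usual scatter of each other, so neither compound stands apart; compound 2 carries the higher figure on paper, but the gap to compound 1 is too small to count as a difference. Both sit far below the reference response.

The next compound, compound 3, `CN1CCC[C@H]1COc1cnccc1Br`, differs from compound 2 in one place: bromo in place of methyl on an aromatic carbon. Among the measured compounds shown here, no step between two measured compounds is available that would show what this exchange does, so the expectation rests only on the two numbers at hand, which are both small and close to each other. On that basis compound 3 is expected to stay in the same low region, and the step of a number 2 percentage points lower from compound 2 to compound 3 (within the scatter) is estimated to be none beyond the scatter. The estimate for compound 3 in this assay is 10%, with a range from 3% to 22%.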

Compound 3, largest response reached (reported as maximum), in percent of the reference or control that the assay uses: 17%
Compound 3: middle estimate off by 7 percentage points, on the low side, within the range that was stated.
By their numbers in this assay, from the lowest: compounds 1, 2 and 3 (each within the scatter of the next).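

In this assay, placing bromo instead of methyl on this aromatic carbon, opposite the ring nitrogen, gives a number 5 percentage points higher from compound 2 to compound 3 (within the scatter), the first step shown between two compounds that differ in one place. At this position, therefore, the read-out does not tell the two groups apart, each of them a single heavy atom with no hydrogen-bond donors or acceptors, and the maximal response is small with both. Nothing available offers an explanation for this outcome.

On these data alone, whether an amine, a carboxylic acid or a longer chain on this same carbon would move the maximal response beyond the scatter remains open, and so a group that differs more from methyl than bromo does could still give a different picture. As far as these compounds go, it is also open whether the same exchange of methyl for bromo would read alike on another carbon of the ring, as this single pair speaks only for the position it occupies.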